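Methyl for Methoxy on a Shared Thiosemicarbazone Core

This account rests on a few compounds, and the source may have more. Where it says the series, first, only, none or still open, it means among the compounds named here.

Measured so far in a functional assay on MCF7 cells (Homo sapiens) for cytotoxicity, read by MTT assay, with a stated time of 48 h; a higher number here means a weaker inhibitor, a lower number a stronger inhibitor:
compound 1, `COc1ccc(NC(=S)N/N=C\c2ccnc3ccccc23)cc1`, 990 nM
compound 2, `S=C(N/N=C\c1ccnc2ccccc12)Nc1cccnc1`, 970 nM
compound 3, `S=C(N/N=C\c1ccnc2ccccc12)Nc1ccc(Cl)cc1`, 1070 nM

Compound 1 stands second highest of the three numbers, with compound 2 nearest, a 1.0-fold lower number from compound 1 to compound 2 (0.01 log units; within the scatter), and compound 3 furthest, a 1.1-fold higher number from compound 1 to compound 3 (0.03 log units; within the scatter). Among the compounds with values here, every step among the three lies within the scatter, including a 1.1-fold higher number from compound 2 to compound 3 (0.04 log units; within the scatter), so no compound can be called stronger or weaker than another on these numbers.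

Compound 4, `Cc1ccc(NC(=S)N/N=C\c2ccnc3ccccc23)cc1`, differs from compound 1 as follows: methyl in place of methoxy on an aromatic carbon. The step that bears most directly on this change is the one in which chloro replaced methoxy on the same aromatic carbon, a 1.1-fold higher number from compound 1 to compound 3 (0.03 log units; within the scatter), which stayed within the scatter. Exchanging the whole ring on the amide-type nitrogen, a 1.0-fold lower number from compound 1 to compound 2 (0.01 log units; within the scatter), did no more. No change at this position has moved the number beyond the scatter, so for compound 4 no step beyond the scatter is expected in this assay in either direction; the expected step is a 1.0-fold higher number from compound 1 to compound 4 (0.00 log units; within the scatter). Compound 4 is therefore estimated at 1000 nM, within a range from 500 nM to 2000 nM.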

Compound 4, half-maximal inhibitory concentration: 980 nM
Estimate against measurement, compound 4: 1.0-fold (0.01 log units) above, within the range that was stated.
By their numbers in this assay, from the lowest: compounds 2, 4, 1 and 3 (each within the scatter of the next).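

Compound 4 adds a third group at this aromatic carbon, para to a large group, and shows that the hydrogen-bond acceptor of the methoxy can go without the number in this assay leaving the scatter: methyl in place of methoxy gave (a 1.0-fold lower number from compound 1 to compound 4 (0.00 log units; within the scatter)), and methyl in place of chloro gave (a 1.1-fold lower number from compound 3 to compound 4 (0.04 log units; within the scatter)). Set against the ring exchange on the amide-type nitrogen, the 4-methylphenyl group likewise gave (a 1.0-fold higher number from compound 2 to compound 4 (0.00 log units; within the scatter)), so the four compounds cannot be told apart on these numbers. No measurement at hand speaks to why these numbers coincide.

On these data alone, whether an amine, a carboxylic acid or a longer alkyl chain on this aromatic carbon would move the number beyond the scatter stays open. As far as these compounds go, all four compounds carry the shared core unchanged, so what a change there would do is also open.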